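Cyclopentyl to isopropyl on the carbamoyl side chain

This account rests on a few compounds, and the source may have more. Where it says the series, first, only, none or still open, it means among the compounds named here.

Compound 2 `CCCn1cc(Cc2ccc(C(=O)NS(=O)(=O)c3ccccc3C)cc2OC)c2cc(C(=O)NCC3CCCC3)ccc21` gives the lowest of the two numbers measured in an assay on lung parenchyma for binding affinity to cysteinyl leukotriene receptor 1 (Cavia porcellus), read by radioligand binding (on this read-out lower numbers stand for stronger inhibition and higher numbers for weaker inhibition), with compound 2 at 0.316 nM; compound 1 `CCCn1cc(Cc2ccc(C(=O)NS(=O)(=O)c3ccccc3C)cc2OC)c2cc(C(=O)NCC(CC)CC)ccc21` gives 0.794 nM. Within the data shown here, the only step measured so far, a 2.5-fold lower number from compound 1 to compound 2 (0.40 log units; beyond the scatter), carries pentan-3-yl to cyclopentyl on a saturated chain carbon bound to an amide-type nitrogen. Compound 3 `CCCn1cc(Cc2ccc(C(=O)NS(=O)(=O)c3ccccc3C)cc2OC)c2cc(C(=O)NCC(C)C)ccc21` takes the same position one further step: isopropyl in place of cyclopentyl on a saturated chain carbon bound to an amide-type nitrogen. Among the measured compounds shown here, the change runs back from the ring toward a branched acyclic group, and the one step in hand shows that the acyclic branched group of compound 1 gave the higher number. A return of roughly that size is therefore expected, not a gain; the step from compound 2 to compound 3 is estimated at a 2.5-fold higher number from compound 2 to compound 3 (0.40 log units; beyond the scatter). Compound 3 is accordingly expected near 0.8 nM, within a range of 0.3 nM to 2 nM.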

Compound 3, inhibition constant: 2 nM
Beside the measured number, compound 3's estimate is 2.5-fold (0.40 log units) below it; measured number inside the range.
By their numbers in this assay, from the lowest: compound 2; then compound 1; then compound 3.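

In this assay the isopropyl group on this saturated chain carbon gives a 6.3-fold higher number from compound 2 to compound 3 (0.80 log units; beyond the scatter) and also falls short of the other acyclic branched group, with a 2.5-fold higher number from compound 1 to compound 3 (0.40 log units; beyond the scatter) beyond the scatter. The order at this position therefore runs cyclopentyl, pentan-3-yl, isopropyl, so the two acyclic branched groups are not interchangeable and the number moves even where no ring is involved. No measurement here bears on why the numbers fall in this order. On these data alone, whether the ring itself or the carbon count of the group sets this order stays open, and cyclobutyl, cyclohexyl or a straight pentyl chain would help separate the two. A tetrahydrofuranyl ring in place of cyclopentyl would show whether a ring oxygen is tolerated here.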